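This account rests on a few compounds, and the source may have more. Where it says the series, first, only, none or still open, it means among the compounds named here.

Compound 1 `Nc1cc(N)c2nc(-c3ccccc3)c(Oc3ccc(Cl)c(Cl)c3)nc2c1` gives 29500 nM in a functional assay on SF-539 cells (Homo sapiens) for inhibition, read by sulforhodamine B assay, with a stated time of 48 h; on this read-out lower numbers stand for stronger inhibition of growth and higher numbers for weaker inhibition of growth. Compound 3 `COc1ccc(Sc2nc3cc(N)cc(N)c3nc2-c2ccccc2)cc1` shows only a limit in this assay, < 100000 nM. Compound 2 `CCOC(=O)[C@H](CCC(=O)O)NC(=O)c1ccc(CNc2nc3cc(N)cc(N)c3nc2-c2ccccc2)cc1` likewise shows only a limit, < 100000 nM. The step that the limit leaves unreadable from compound 1 to compound 3 therefore cannot be read, because two of the three values sit at the limit of < 100000 nM in this assay, at which 2 of the 3 values shown sit. Compound 4 `Nc1cc(N)c2nc(-c3ccccc3)c(Oc3ccc(F)cc3)nc2c1` differs from compound 3 by 4-fluorophenoxy in place of (4-methoxyphenyl)sulfanyl on an aromatic carbon. Going by the values given here, no measured step bears directly on this change; the only related pair, compound 1 against compound 3, is hidden by the limit. Compound 4 resembles compound 1 in the oxygen link to the ring, and compound 1 with its 29500 nM is the nearest anchor. Compound 4 is expected near 40000 nM, between 10000 nM and 100000 nM. The step that the limit leaves unreadable from compound 3 to compound 4 is an estimate only, set against a limit.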

Compound 4, concentration for total growth inhibition: 35500 nM
Estimate against measurement, compound 4: 1.1-fold (0.05 log units) above; the measured number falls inside the stated range.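

With the oxygen link kept on the aromatic carbon next to the ring nitrogen, 4-fluorophenyl in place of 3,4-dichlorophenyl is a 1.2-fold higher number from compound 1 to compound 4 (0.08 log units; within the scatter) in this assay. Going by these compounds alone, this is the first readable step at this position, and it shows that this change on the aryl group stays within the scatter. The steps involving compound 3 cannot be read: the limit of < 100000 nM in this assay, at which 2 of the 4 values shown sit.

From the compounds shown here alone, whether a sulfur link differs from an oxygen link at this position stays open. So does the outcome of a morpholine or a nitrile in place of the aryloxy group.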